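The source may report more compounds than this note shows. Statements on the series, on what has been measured and on what is new or still open speak of the compounds shown alone.

Compound 1 `COC(=O)/C=C/c1cccc(N(Cc2ccc(/C=C/c3ccc(F)cc3)cc2)C(=O)C(C)C)c1`: 120 nM
Compound 2 `COC(=O)/C=C/c1cccc(N(Cc2ccc(-c3cccc(Cl)c3)cc2)C(=O)C(C)C)c1`: 77 nM
Compound 3 `COC(=O)/C=C/c1cccc(N(Cc2ccc(-c3cccc(C)c3)cc2)C(=O)C(C)C)c1`: 163 nM

In an assay on isolated protein with Bile acid receptor (Homo sapiens) as the target (a lower number here means that less compound is needed, a higher number that more compound is needed for the effect), compound 3 gives the highest of the three numbers. Its step from compound 2 is a 2.1-fold higher number from compound 2 to compound 3 (0.33 log units; beyond the scatter), while the step of a 1.4-fold higher number from compound 1 to compound 3 (0.13 log units; within the scatter) stays within the scatter, as does a 1.6-fold lower number from compound 1 to compound 2 (0.19 log units; within the scatter). Compound 4 `COC(=O)/C=C/c1cccc(N(Cc2ccc(-c3ccc(OC(F)(F)F)cc3)cc2)C(=O)C(C)C)c1` carries 4-(trifluoromethoxy)phenyl in place of 3-methylphenyl on an aromatic carbon. Going by the values given here, no measured pair varies the group on the phenyl in this way, so the only comparison between two such groups is a 2.1-fold higher number from compound 2 to compound 3 (0.33 log units; beyond the scatter), a modest one. A step of about that size, towards a lower number, is expected for compound 4, and compound 4 is therefore estimated at 90 nM, with a range of 40 nM to 220 nM in this assay. That estimate means an expected step of a 1.8-fold lower number from compound 3 to compound 4 (0.26 log units; within the scatter).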

Compound 4, half-maximal effective concentration: 219 nM
For compound 4 the middle estimate is 2.4-fold (0.39 log units) below the measured one, within the range that was stated.
By their numbers in this assay, from the lowest: compounds 2, 1, 3 and 4 (each within the scatter of the next, the first and the last beyond it).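

In this assay, replacing 3-methylphenyl with 4-(trifluoromethoxy)phenyl, with its larger heavy-atom count and one hydrogen-bond acceptor, gives a 1.3-fold higher number from compound 3 to compound 4 (0.13 log units; within the scatter); replacing 2-(4-fluorophenyl)ethenyl gives a 1.8-fold higher number from compound 1 to compound 4 (0.26 log units; within the scatter). Replacing 3-chlorophenyl gives a 2.8-fold higher number from compound 2 to compound 4 (0.45 log units; beyond the scatter), so among these groups only 3-chlorophenyl separates from 4-(trifluoromethoxy)phenyl. No measured evidence explains these steps.

The 3-chlorophenyl and 4-(trifluoromethoxy)phenyl groups differ in both substituent and substituent place, so the two effects remain unseparated. Also open, as far as these compounds go, is how 4-chlorophenyl, or a phenyl carrying an amine or a carboxylic acid, would read here.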